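The compounds below may be only part of what the source reports. "The series", "measured", "known", "first", "only" and "open" are said of these compounds alone.

Measured in an ADME assay on Jurkat cells (Homo sapiens) for cytotoxicity, read by MTT assay; on this read-out lower numbers stand for stronger inhibition and higher numbers for weaker inhibition:
- Compound 1 `O/N=C(\COc1cccc2ccccc12)c1ccc(Cl)cc1`: > 50000 nM
- Compound 2 `O/N=C(\COc1cccc2ccccc12)c1ccc(C(F)(F)F)cc1`: > 50000 nM

Compound 2 stands at > 50000 nM, which is a limit of the assay and not a number. Compound 1 gives > 50000 nM, which is also a limit. Both measured compounds sit at the same limit: the limit of > 50000 nM in this assay, at which 2 of the 2 values shown sit. Compound 3 `O/N=C(\COc1cccc2ccccc12)c1ccc(-c2ccccc2)cc1` carries phenyl in place of trifluoromethyl on an aromatic carbon. Within the data shown here, the only measured step, a step that the two limits leave unreadable from compound 1 to compound 2, offers no size to carry over. In this assay, no step beyond the scatter is therefore expected, and compound 3 is expected to stay close to the limit. Any readable number would be expected on the side of stronger inhibition. The estimate means an expected a number no higher from compound 2 to compound 3 (the limit leaves the size open). For compound 3 the estimated value is 50000 nM, with an expected range from 20000 nM to 100000 nM.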

Compound 3, half-maximal inhibitory concentration: > 50000 nM
Compound 3: only a limit was reported; the forecaster's own chance of this, stated with the estimate: 70%; the middle value sits exactly at the limit.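

Compound 3 gives > 50000 nM in this assay, which is a limit of the assay and not a number. No step can be read among compound 1, compound 2 and compound 3, which all share one limit: the limit of > 50000 nM in this assay, at which 3 of the 3 values shown sit. The compounds shown leave open whether chloro, trifluoromethyl and phenyl differ at all on this read-out.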